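The source may report more compounds than this note shows. Statements on the series, on what has been measured and on what is new or still open speak of the compounds shown alone.

Values measured in a functional assay on MDA-MB-231 cells (Homo sapiens), read by microscopy and transwell migration, with a stated time of 3.5 h (on this read-out lower numbers stand for stronger inhibition and higher numbers for weaker inhibition), for three compounds

- Compound 1 `COc1cc2c(Oc3ccc(NS(=O)(=O)c4ccccc4C(F)(F)F)cc3F)ccnc2cc1OCCCN1CCN(C)CC1` gives 4600 nM
- Compound 2 `COc1cc2c(Oc3ccc(NS(=O)(=O)c4ccccc4OC(F)(F)F)cc3F)ccnc2cc1OCCCN1CCN(C)CC1` gives 4300 nM
- Compound 3 `COc1cc2c(Oc3ccc(NS(=O)(=O)c4cc(F)ccc4F)cc3F)ccnc2cc1OCCCN1CCN(C)CC1` gives 2500 nM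

Compound 3 cannot be separated from the other two. The data show a 1.8-fold lower number from compound 1 to compound 3 (0.26 log units; within the scatter) and a 1.7-fold lower number from compound 2 to compound 3 (0.24 log units; within the scatter) and the remaining pair shows a 1.1-fold lower number from compound 1 to compound 2 (0.03 log units; within the scatter) as well.

Compound 4 `COc1cc2c(Oc3ccc(NS(=O)(=O)c4cc(F)ccc4F)cc3F)ccnc2cc1OCCCN1CCCC(C)C1` keeps the aromatic group on the sulfonyl sulfur of compound 3 and differs at the far end of the chain. There, 3-methylpiperidin-1-yl in place of 4-methylpiperazin-1-yl on a saturated chain carbon, three bonds along the chain from an oxygen on an aromatic ring is the whole difference.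

Within the data shown here, none of the measured steps touches this group. All three changed the aromatic group on the sulfonyl sulfur, so they say nothing direct about the new ring and show only that the set has moved little so far. The expectation therefore starts from compound 3 at 2500 nM and keeps a wide margin.

The step expected in this assay is a 1.1-fold lower number from compound 3 to compound 4 (0.06 log units; within the scatter) and nothing beyond the scatter is foreseen. The estimate for compound 4 is 2200 nM with an expected range from 800 nM to 6000 nM as the likely span.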

Compound 4, half-maximal inhibitory concentration: 3300 nM
For compound 4 the middle estimate is 1.5-fold (0.18 log units) below the measured one, and the stated range covers the measured number.
By their numbers in this assay, from the lowest: compounds 3, 4, 2 and 1 (each within the scatter of the next).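

Unlike the earlier steps, which all changed the aromatic group on the sulfonyl sulfur, this one changes the far end of the chain. In this assay, 3-methylpiperidin-1-yl in place of 4-methylpiperazin-1-yl gives a 1.3-fold higher number from compound 3 to compound 4 (0.12 log units; within the scatter) and so shows that, for this pair, a ring with one hetero atom instead of two leaves the number within the scatter. No measurement shown here offers an explanation for this result.

The swap alters the ring's hetero atoms and the place of its methyl group together, so this pair cannot separate the two changes, and a plain piperidin-1-yl or a morpholin-4-yl ring at the same place would bear on that. Going by these compounds, it is also open whether the same swap behaves alike with the 2-(trifluoromethyl)phenyl group on the sulfonyl sulfur, or on a shorter two-carbon chain.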